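Moving the amine around on the aryl group of compound 1

A few compounds are considered here, and "the series" means these few. Any claim that something is new, unique, unknown or untested is made for them only; others in the source may bear on it.

Working notes on a small set of regioisomers sharing one core. Compound 1 `COc1cc(-c2ncnn2-c2cccc(N)c2)cc(OC)c1OC` carries a 3-aminophenyl on an aromatic nitrogen of the core. In a functional assay on K562 cells (Homo sapiens) for antiproliferative activity, read by MTT assay, with a stated time of 72 h (a lower number here means a stronger inhibitor, a higher number a weaker inhibitor), compound 1 gives only a limit, > 10000 nM, so no number is known for it. Compound 2 `COc1cc(-n2ncnc2-c2ccc(C)cc2)cc(OC)c1OC` has the same core with the aryl groups arranged differently. In this assay compound 2 likewise gives only a limit, > 10000 nM. Both values shown therefore sit at the same point, (the limit of > 10000 nM in this assay, at which 2 of the 2 values shown sit), and nothing separates them in this read-out.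

The next compound, compound 3 `COc1cc(-c2ncnn2-c2ccc(N)cc2)cc(OC)c1OC`, differs from compound 1 in one place: 4-aminophenyl in place of 3-aminophenyl on an aromatic nitrogen. For the measured compounds named here, no measured pair in this set differs in one place, so there is no observed step to lean on. Given that compound 1 sits at the limit, the step from compound 1 to compound 3 is expected to be small, most likely none beyond the scatter, a step that the limit leaves unreadable from compound 1 to compound 3. For compound 3 in this assay an estimate of 15000 nM is made, with a range from 4000 nM to 50000 nM, and a limit rather than a number is thought the more likely outcome.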

Compound 3, half-maximal inhibitory concentration: > 10000 nM
Compound 3: no number, only a limit; the forecaster's own chance of this, stated with the estimate: 70%; the middle value is on the limit's open side.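

In this assay compound 3 gives > 10000 nM as a limit and not a number. For the compounds shown here, no step from compound 1 to compound 3 can be read, since both stand at a limit: the limit of > 10000 nM in this assay, at which 3 of the 3 values shown sit.

The compounds shown leave open how 3-aminophenyl and 4-aminophenyl compare, and whether any arrangement of the aryl groups on the shared core gives a measurable value.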